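The source may hold more compounds than are shown below. What is called first, only, known or untested is meant among the compounds shown, and "the series" means these compounds.

Measured compounds in a functional assay on CHO cells for agonist activity at Alpha-2B adrenergic receptor (Homo sapiens); on this read-out lower numbers stand for smaller maximal responses and higher numbers for larger maximal responses:
Compound 1, `CC(Oc1ccccc1-c1cccnc1)C1=NCCN1`: 0.5.
Compound 2, `CC(Oc1ccccc1-c1ccncc1)C1=NCCN1`: a limit of the assay, < 0.3.
Compound 3, `CC(Oc1ccccc1-c1ccccc1O)C1=NCCN1`: a limit of the assay, < 0.3.

Compound 3 thus stands at the floor of what this assay reports, and only a limit, not a number, is known for it; it is one of the two compounds sitting at the limit of < 0.3 in this assay, at which 2 of the 3 values shown sit. Compound 4, `Cc1cccc(-c2ccccc2OC(C)C2=NCCN2)c1`, has not yet been measured. It differs from compound 3 by 3-methylphenyl in place of 2-hydroxyphenyl on an aromatic carbon. For the measured compounds named here, no measured step involves 3-methylphenyl. Going by the values given here, the steps that bear on this position are a number at least 0.20 lower from compound 1 to compound 3 (beyond the scatter) and a number at least 0.20 lower from compound 1 to compound 2 (beyond the scatter), while a step that the two limits leave unreadable from compound 2 to compound 3. Both readable steps show that exchanging pyridin-3-yl for another group at this place brought the response down to the limit, so a clear rise for a third exchange cannot be assumed. Compound 4 is expected to stay near the limit, with the expected step of a number no lower from compound 3 to compound 4 (the limit leaves the size open) small and not clearly beyond the scatter. The estimate for compound 4 is 0.3, between 0.15 and 0.6.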

Compound 4, intrinsic activity: the largest response reached, as a fraction of the reference agonist's: < 0.3
Compound 4 ended at the assay's limit (the forecaster's own chance of this, stated with the estimate: 45%); the middle value lies on the limit itself.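

In this assay, exchanging pyridin-3-yl for 3-methylphenyl gives a number at least 0.20 lower from compound 1 to compound 4 (beyond the scatter). This is the third group at this place to fall short of pyridin-3-yl, and unlike 2-hydroxyphenyl, which has 1 hydrogen-bond donor and 1 hydrogen-bond acceptor, 3-methylphenyl has 0 of each, so a group without them gives no better-defined response here. Compound 4 joins compounds 2 and 3 at a limit of the assay, which leaves compound 1 as the only one of the four with an actual number: the limit of < 0.3 in this assay, at which 3 of the 4 values shown sit.

As far as these compounds go, the steps among compounds 2, 3 and 4 cannot be read, so the order of these three groups remains unknown. Also open, from the compounds shown here alone, is whether another group at this place, such as pyrimidin-5-yl or 3-aminophenyl, would give a response clear of the limit.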